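A few compounds are considered here, and "the series" means these few. Any claim that something is new, unique, unknown or untested is made for them only; others in the source may bear on it.

Working notes on the series.

The shared core carries a hydroxyl and a methylidene on the saturated part, a phenol or its tosylate on the aromatic part, and a triazole bearing a para-substituted phenyl. Compound 1 `C=C1C[C@]23C[C@@]1(O)CC[C@H]2c1ccc(OS(=O)(=O)c2ccc(C)cc2)c(C)c1[C@@H]3Cn1cc(-c2ccc(OC)cc2)nn1` and compound 2 `C=C1C[C@]23C[C@@]1(O)CC[C@H]2c1ccc(OS(=O)(=O)c2ccc(C)cc2)c(C)c1[C@@H]3Cn1cc(-c2ccc(C)cc2)nn1` both carry the tosylate; compound 3 `C=C1C(=O)[C@]23C[C@@]1(O)CC[C@H]2c1ccc(O)c(C)c1[C@@H]3Cn1cc(-c2ccc(C)cc2)nn1` carries the free phenol and a carbonyl in place of the ring methylene. In a functional assay on SMMC-7721 cells (Homo sapiens) for cytotoxicity, read by MTT assay, with a stated time of 4 days (a lower number here means a stronger inhibitor, a higher number a weaker inhibitor), compound 1 gives > 20000 nM, which is a limit of the assay and not a number. In this assay compound 2 likewise gives > 20000 nM, again only a limit. Among the compounds with values here, compound 3 is the single compound here with a number: in this assay compound 3 gives 920 nM. The step from compound 2 to compound 1, a step that the two limits leave unreadable from compound 2 to compound 1, is methoxy in place of methyl on an aromatic carbon; its size cannot be read because the limit of > 20000 nM in this assay, at which 2 of the 3 values shown sit, holds both ends. How the core of compound 3 differs from that of compound 2 is not broken down here.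

Within the data shown here, compound 4 `C=C1C(=O)[C@]23C[C@@]1(O)CC[C@H]2c1ccc(O)c(C)c1[C@@H]3Cn1cc(-c2ccc(OC)cc2)nn1` is the not yet measured partner of compound 3: the change methoxy in place of methyl on an aromatic carbon is the same change as the one from compound 2 to compound 1, at the same place. Because a step that the two limits leave unreadable from compound 2 to compound 1 is unreadable, nothing measured sets the size of the expected step; the expectation therefore rests on compound 3 alone, whose value 920 nM is taken as the anchor, and the step from compound 3 to compound 4 is expected to be a 1.1-fold higher number from compound 3 to compound 4 (0.04 log units; within the scatter), within the usual scatter. For compound 4 the expected value in this assay is 1000 nM, estimated to lie between 400 nM and 3000 nM.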

Compound 4, half-maximal inhibitory concentration: 860 nM
The estimate for compound 4 lay 1.2-fold (0.07 log units) above the measured number; the measured number falls inside the stated range.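

On the core of compound 3, the free phenol with the ring carbonyl, the change from 4-methylphenyl to 4-methoxyphenyl gives a 1.1-fold lower number from compound 3 to compound 4 (0.03 log units; within the scatter) in this assay, so on this core the two groups cannot be told apart in this read-out. On the tosylate core the same change cannot be read, because both of its ends are limits of the assay and not numbers: the limit of > 20000 nM in this assay, at which 2 of the 4 values shown sit. The series therefore holds one readable instance of this change, on one core, and it does not show that the change carries from one core to the other, nor that methyl and methoxy would also read alike on the tosylate core if values were obtained there.

The compounds shown leave open how other groups at this place on the phenyl ring would read, for example an amine, a carboxylic acid or a longer alkoxy chain such as butoxy, as only methyl and methoxy appear there. Within the data shown here, also open is how the two core differences divide, the tosylate against the free phenol and the ring methylene against the carbonyl, as they occur together here and no pair separates them.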